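From Amide to Acid: Expecting Little Change

A few compounds are considered here, and "the series" means these few. Any claim that something is new, unique, unknown or untested is made for them only; others in the source may bear on it.

Of the compounds shown here, three have been measured in a functional assay on the whole organism (stomach) for inhibition, with Rattus norvegicus as the target, at a dose of 100 mg/kg by the intraduodenal route; a higher number here means more inhibition at the dose given (going by the name of the read-out), a lower number less inhibition. Compound 1 `O=c1cccnn1CCC(=S)N1CCCC1` gives 29.7% in this assay, and compound 2 `C/N=C(\S)C(C)Cn1ncccc1=O` gives 50.2%. Compound 3 `NC(=O)CCn1nc(-c2ccccc2)ccc1=O` gives -2.8%, the lowest of the three numbers, with gaps to both other compounds beyond the usual scatter.

Compound 4 `O=C(O)CCn1nc(-c2ccccc2)ccc1=O` differs from compound 3 in a single place: hydroxy in place of amino on a carbonyl carbon. For the measured compounds named here, no measured pair shows this change, so its effect cannot be read from the data; the only guide is that compound 3 shows essentially no inhibition. The expected step is a number 5.8 percentage points higher from compound 3 to compound 4 (within the scatter), which is no change beyond the scatter. Compound 4 is therefore estimated at 3%, somewhere between -15% and 22%.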

Compound 4, a percentage reported as inhibition, in the whole organism at one dose (the size of the read-out at that dose, not a potency): 26.1%
For compound 4 the middle estimate is 23.1 percentage points below the measured one; the whole stated range lies below it.
By their numbers in this assay, from the lowest: compound 3; then compounds 4 and 1 (each within the scatter of the next); then compound 2.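

Replacing amino with hydroxy on the carbonyl carbon, which turns the 2-carbamoylethyl group into 2-carboxyethyl, gives a number 28.9 percentage points higher from compound 3 to compound 4 (beyond the scatter) in this assay while the rest of the molecule stays the same. For the compounds shown here, this is the first single-place comparison in the set, and it shows that the read-out responds to what sits on this carbonyl carbon. No measurement shown here explains the step.

Still open, going by these compounds, is how a methyl ester at this place, or a longer chain carrying the carboxy group, would compare with compound 4. A single pair also cannot show whether this swap would have a similar effect on another core.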